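The source may report more compounds than this note shows. Statements on the series, on what has been measured and on what is new or still open speak of the compounds shown alone.

The shared core carries a piperidin-1-yl group in compound 1 `Cn1cnc2c(N3CCCCC3)nc(-c3ccccc3O)nc21` and in compound 3 `Cn1cnc2c(N3CCCCC3)nc(-c3cccc(O)c3O)nc21`, while compound 2 `CN1CCN(c2nc(-c3cccc(O)c3)nc3c2ncn3C)CC1` carries a different amine. In an assay on cells for displacement of a labelled ligand from adenosine receptor A1 (Homo sapiens), read by scintillation counting and radioligand binding, with a stated time of 60 min, tested at 10 uM (on this read-out lower numbers stand for less inhibition and higher numbers for more inhibition at the one concentration tested (going by the name of the read-out)), compound 1 gives 50.5%, compound 2 gives 27.1% and compound 3 gives 17.2%. Among the measured compounds shown here, compound 3 therefore stands lowest of the three numbers, with compound 2 within the scatter of it and compound 1 beyond it; the one single-point step, hydroxy in place of hydrogen on an aromatic carbon, is large, a number 33.3 percentage points lower from compound 1 to compound 3 (beyond the scatter). Compound 4 `Cn1cnc2c(N3CCCCC3)nc(-c3cc(Cl)ccc3Cl)nc21` differs from compound 3 in one place: 2,5-dichlorophenyl in place of 2,3-dihydroxyphenyl on an aromatic carbon. For the measured compounds named here, no measured step covers this exchange; the step of a number 33.3 percentage points lower from compound 1 to compound 3 (beyond the scatter) only shows that an added hydroxy lowered the number, whereas here both hydroxy groups leave and two chlorines enter. Compound 4 is thus expected, with wide uncertainty, to give 35%, between 5% and 65%. The estimated step of a number 17.8 percentage points higher from compound 3 to compound 4 (beyond the scatter) is expected to point upward, though possibly within the scatter.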

Compound 4, a percentage reported as inhibition, at one concentration (the size of the read-out at that concentration, not a potency): 13.2%
Compound 4: middle estimate off by 21.8 percentage points, on the high side, within the range that was stated.
By their numbers in this assay, from the lowest: compounds 4, 3 and 2 (each within the scatter of the next, the first and the last beyond it); then compound 1.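

In this assay, the place between two ring nitrogen atoms takes 2,5-dichlorophenyl and 2,3-dihydroxyphenyl with numbers that cannot be told apart, a number 4 percentage points lower from compound 3 to compound 4 (within the scatter). Compound 4 has no hydroxy group and no hydrogen-bond donors on this ring, yet it still sits low, a number 37.3 percentage points lower from compound 1 to compound 4 (beyond the scatter), so a low number here does not require hydroxy groups, and the 2-hydroxyphenyl of compound 1 stands apart from both other aryl groups on the piperidin-1-yl core. No evidence is available on why these aryl groups give these numbers.

As far as these compounds go, it remains open whether the higher number of compound 1 depends on the hydroxy hydrogen itself, which a 2-methoxyphenyl group would test. From the compounds shown here alone, an unsubstituted phenyl or a 2-aminophenyl group at this place also remains open.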